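A Propargyl Amide Tested for Tolerance on Liver Cells

The source may hold more compounds than are shown below. What is called first, only, known or untested is meant among the compounds shown, and "the series" means these compounds.

Compound 1 `COc1ccc2nc(C)cc(OCC(=O)Nc3ccc(Br)cc3)c2c1` was examined in an ADME assay on HepG2 cells (Homo sapiens) for cytotoxicity, read by trypan blue exclusion, with a stated time of 48 h, in the presence of a further agent that is not named here; a higher number here means that more compound is tolerated, a lower number that less compound is tolerated. For compound 1 the result is only a limit, > 125000 nM. Among the measured compounds shown here, its single measured neighbour, compound 2 `COc1ccc2nc(C)cc(OCC(=O)Nc3ccc(-c4ccccc4)cc3)c2c1`, likewise gives only a limit in this assay, > 126000 nM. The step between them, a step that the two limits leave unreadable from compound 1 to compound 2, cannot be sized, since the limit of > 125000 nM in this assay, at which 1 of the 2 values shown sits, and the limit of > 126000 nM in this assay, at which 1 of the 2 values shown sits, are all that is recorded for the pair.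

Compound 3 `C#CCNC(=O)COc1cc(C)nc2ccc(OC)cc12` has not yet been measured in this assay. It differs from compound 1 in one place: propargyl in place of 4-bromophenyl on an amide-type nitrogen.

For the measured compounds named here, no measured step bears directly on this change. Going by the values given here, the one step in hand swaps a group on an aromatic carbon, not on the amide-type nitrogen, and its size is unreadable in any case. With both measured compounds resting at a limit, there is no basis for expecting a move beyond the scatter in either direction. The step expected is a step that the limit leaves unreadable from compound 1 to compound 3, a forecast rather than an observation. Compound 3 is estimated at 150000 nM, in a range from 60000 nM to 400000 nM, and most probably the assay will again report only a limit.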

Compound 3, half-maximal cytotoxic concentration: > 176000 nM
Compound 3: no number, only a limit; the forecaster's own chance of this, stated with the estimate: 80%; middle value at least 1.1-fold (0.06 log units) from the limit.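

In this assay, compound 3 gives only a limit, > 176000 nM. Among the compounds shown here, compound 1 also rests at a limit, so no step from compound 1 to compound 3 can be read. The compounds shown leave open the half-maximal cytotoxic concentration of compound 1, compound 2 and compound 3, and whether propargyl in place of 4-bromophenyl changes it at all.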